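The source may hold more compounds than are shown below. What is called first, only, known or untested is meant among the compounds shown, and "the series" means these compounds.

In a functional assay on SW480 cells (Homo sapiens) for cytotoxicity, read by MTT assay, with a stated time of 48 h (on this read-out lower numbers stand for stronger inhibition and higher numbers for weaker inhibition), compound 1 `Cc1cccc(Cn2cc(COc3ccc4c(=O)ccoc4c3)nn2)c1` gives 11700 nM, and compound 2 `O=c1ccoc2cc(OCc3cn(Cc4ccc(F)cc4)nn3)ccc12` gives 11200 nM. Among the measured compounds shown here, the one measured step is a 1.0-fold lower number from compound 1 to compound 2 (0.02 log units; within the scatter). Compound 2 thus gives the lower of the two numbers shown, but the gap to compound 1 is within the scatter, so neither can be called stronger. Compound 3 `O=c1ccoc2cc(OCc3cn(Cc4ccc([N+](=O)[O-])cc4)nn3)ccc12` differs from compound 2 by nitro in place of fluoro on an aromatic carbon. For the measured compounds named here, the only measured step, which also exchanged the group on this phenyl ring, stayed within the scatter, so in this assay the step of a 1.0-fold lower number from compound 2 to compound 3 (0.01 log units; within the scatter) is expected to be none beyond the scatter. Compound 3 is therefore estimated at 11000 nM, within 5000 nM to 25000 nM.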

Compound 3, half-maximal inhibitory concentration: 19300 nM
Compound 3: the middle estimate sits 1.8-fold (0.24 log units) below what was measured, and the stated range covers the measured number.
By their numbers in this assay, from the lowest: compounds 2, 1 and 3 (each within the scatter of the next).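

Even nitro, with its 3 heavy atoms and 2 hydrogen-bond acceptors in place of fluoro, leaves this assay within the scatter on this aromatic carbon: a 1.7-fold higher number from compound 2 to compound 3 (0.24 log units; within the scatter). Compared with the 3-methylphenyl group, the 4-nitrophenyl group also stays within the scatter, with a 1.6-fold higher number from compound 1 to compound 3 (0.22 log units; within the scatter), so these three groups cannot be told apart here. No evidence on hand bears on this result. Going by these compounds, it remains open whether an amine or a carboxylic acid on this ring, or a longer chain in place of the saturated chain carbon, would move the number beyond the scatter.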